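Adding a methoxycarbonyl group to compound 1

A few compounds are considered here, and "the series" means these few. Any claim that something is new, unique, unknown or untested is made for them only; others in the source may bear on it.

Measured so far in an ADME assay on KB cells (Homo sapiens) for cytotoxicity, read by MTT assay, with a stated time of 72 h; on this read-out higher numbers stand for weaker inhibition and lower numbers for stronger inhibition
- compound 1 (`COc1ccc(C2=C(c3cc(OC)c(OC)c(OC)c3)C(=O)CC2O[SiH2]C(C)(C)C)cc1`) gives > 100 ug/mL
- compound 2 (`COc1cc(C2=C(c3cc(C)c(OC)c(C)c3)C(OC(C)=O)CC2=O)cc(OC)c1OC`) gives > 100 ug/mL

In this assay compound 1 gives > 100 ug/mL and this is a limit of the assay, not a number. The evidence is thin, with the limit of > 100 ug/mL in this assay, at which 2 of the 2 values shown sit, and no true number yet.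

Compound 3 (`COC(=O)c1cc(C2=C(c3cc(OC)c(OC)c(OC)c3)C(=O)CC2O[SiH2]C(C)(C)C)ccc1OC`) has not been measured. It differs from compound 1 by methoxycarbonyl in place of hydrogen on an aromatic carbon and has methoxycarbonyl in place of hydrogen on an aromatic carbon, ortho to a methoxy group. Within the data shown here, with compound 1 resting on the limit of > 100 ug/mL in this assay, at which 2 of the 2 values shown sit, as the only guide, no step beyond the usual scatter is expected in this assay in either direction (estimated as a number no higher from compound 1 to compound 3 (the limit leaves the size open)). The estimate for compound 3 is 100 ug/mL (expected range 30 ug/mL to 200 ug/mL).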

Compound 3, half-maximal inhibitory concentration: > 100 ug/mL
Compound 3: no number, only a limit; the forecaster's own chance of this, stated with the estimate: 75%; the middle value lies on the limit itself.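

In this assay compound 3 gives > 100 ug/mL, a limit of the assay and not a number. Among these compounds, compound 1 also rests on a limit, and no step between compound 1 and compound 3 can be read. The compounds shown leave open whether methoxycarbonyl changes cytotoxicity at all.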